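A further methyl on compound 2

The source may report more compounds than this note shows. Statements on the series, on what has been measured and on what is new or still open speak of the compounds shown alone.

Compound 1 `Cc1ccccc1OCC(O)CNCCC(=O)Nc1ccc(C2=NNC(=O)CC2)cc1` gives 6 umol/kg
Compound 2 `Cc1ccccc1OCC(O)CNCCC(=O)Nc1ccc(C2=NNC(=O)CC2C)cc1` gives 2 umol/kg
Compound 3 `O=C1CCC(c2ccc(NC(=O)CNCC(O)COc3cccc4ccccc34)cc2)=NN1` gives 1.4 umol/kg

In a functional assay on the whole organism with Rattus norvegicus as the target (on this read-out higher numbers stand for an effect only at larger amounts of compound and lower numbers for an effect already at smaller amounts), compound 2 stands within the scatter of compound 3 and clearly apart from compound 1. Compound 4 `Cc1cccc(OCC(O)CNCCC(=O)Nc2ccc(C3=NNC(=O)CC3C)cc2)c1C` differs from compound 2 by one change, methyl in place of hydrogen on an aromatic carbon, turning 2-methylphenyl into 2,3-dimethylphenyl. For the measured compounds named here, the one measured step (a 3.0-fold lower number from compound 1 to compound 2 (0.48 log units; beyond the scatter)) is also methyl for hydrogen, but on a saturated ring carbon, so it bears only loosely on this change. Going by the values given here, no measured step touches the aromatic carbon, so no shift beyond the scatter is expected. The expected step is small (a 1.2-fold lower number from compound 2 to compound 4 (0.07 log units; within the scatter)). Compound 4 is estimated at 1.7 umol/kg (expected range 0.6 umol/kg to 5 umol/kg).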

Compound 4, dose for half-maximal effect: 2.4 umol/kg
Estimate against measurement, compound 4: 1.4-fold (0.15 log units) below; measured number inside the range.
By their numbers in this assay, from the lowest: compounds 3, 2 and 4 (each within the scatter of the next); then compound 1.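

In this assay, adding a methyl to the aromatic ring, turning 2-methylphenyl into 2,3-dimethylphenyl, gives a 1.2-fold higher number from compound 2 to compound 4 (0.08 log units; within the scatter) and so leaves the number within the scatter. This aromatic carbon, ortho to a methyl group, therefore accepts a methyl with no readable change, whereas the methyl on the saturated ring carbon gave a 3.0-fold lower number from compound 1 to compound 2 (0.48 log units; beyond the scatter), a step beyond the scatter. From the compounds shown here alone, whether a methoxy group, a chlorine atom or an amine on this same carbon would also leave the number in place remains open. Nothing measured here explains why this methyl changes so little.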